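The source may report more compounds than this note shows. Statements on the series, on what has been measured and on what is new or still open speak of the compounds shown alone.

In a functional assay on HeLa cells (Homo sapiens) for inhibition, read by CCK-8 assay, with a stated time of 72 h, tested at 8 uM (on this read-out lower numbers stand for less inhibition of growth and higher numbers for more inhibition of growth at the one concentration tested), three compounds have been measured so far. Compound 1 `Nc1ccccc1NC(=O)/C=C/c1ccc(CSc2ccc(C(F)(F)F)cn2)cc1` gives 6.82%, compound 3 `COC(=O)c1ccccc1SCc1ccc(C(=O)Nc2ccccc2N)cc1` gives 55.5%, and compound 2 `Cc1ccc(SCc2ccc(C(=O)Nc3ccccc3N)cc2)cc1` gives 79.2%. Compound 2 is the highest of the three, and its gap to each of the others lies beyond the scatter. The next step leads from compound 2 to compound 4 `Cc1cc(C)cc(SCc2ccc(C(=O)Nc3ccccc3N)cc2)c1`: 3,5-dimethylphenyl in place of 4-methylphenyl on a sulfur. In words, this puts 3,5-dimethylphenyl in place of 4-methylphenyl on a sulfur. Going by the values given here, no measured pair yet isolates a change at this place, so the expectation is cautious: a slight fall, probably none beyond the scatter. The expected change in this assay is a number 7.2 percentage points lower from compound 2 to compound 4 (within the scatter). For compound 4 the estimated value is 72%, with an expected range of 52% to 88%.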

Compound 4, percent growth inhibition at one concentration: 78.9%
Compound 4: the middle estimate sits 6.9 percentage points below what was measured, and the stated range covers the measured number.
By their numbers in this assay, from the lowest: compound 1; then compound 3; then compounds 4 and 2 (each within the scatter of the next).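

In this assay, going by these compounds alone, 3,5-dimethylphenyl in place of 4-methylphenyl on a sulfur gives a number 0.3 percentage points lower from compound 2 to compound 4 (within the scatter), the first measured step at this position. The two compounds cannot be told apart here, so at this one concentration, growth inhibition is kept with either of these two methyl-bearing phenyl groups on the sulfur. No measured evidence offers an explanation for this result. On these data alone, whether the same holds for an amine or a carboxylic acid on this phenyl ring remains open. A single concentration also leaves open whether the two compounds would match across a range of doses.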